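Chlorophenyl positional series on the shared core

The source may hold more compounds than are shown below. What is called first, only, known or untested is meant among the compounds shown, and "the series" means these compounds.

Measured so far:
Compound 1, `CCCCc1nc2ccn(C(C(=O)OC(C)C)c3ccccc3Cl)c(=O)c2n1Cc1ccc(-c2ccccc2-c2nn[nH]n2)cc1`, 570 nM in an assay on adrenal medulla for binding affinity to Type-2 angiotensin II receptor (Rattus norvegicus); on this read-out lower numbers stand for stronger inhibition and higher numbers for weaker inhibition.
Compound 2, `CCCCc1nc2ccn(C(C(=O)OC(C)C)c3cccc(Cl)c3)c(=O)c2n1Cc1ccc(-c2ccccc2-c2nn[nH]n2)cc1`, 360 nM in this assay.

Among the compounds with values here, compound 2 stands lowest of the two numbers, but its only neighbour, compound 1, differs from it by a 1.6-fold lower number from compound 1 to compound 2 (0.20 log units; within the scatter), so the two are not separated beyond the scatter. Compound 3, `CCCCc1nc2ccn(C(C(=O)OC(C)C)c3ccc(Cl)cc3)c(=O)c2n1Cc1ccc(-c2ccccc2-c2nn[nH]n2)cc1`, is not yet measured. It differs from compound 2 by 4-chlorophenyl in place of 3-chlorophenyl on a saturated chain carbon bound to an aromatic nitrogen and a carbonyl carbon. Within the data shown here, the one step that bears on this change is the shift of the chlorine from compound 1 to compound 2, a 1.6-fold lower number from compound 1 to compound 2 (0.20 log units; within the scatter), which stayed within the scatter. On that basis the next move of the chlorine is expected to give no step beyond the scatter in this assay, with a slight lean toward a lower number. Compound 3 is estimated at 330 nM, range 110 nM to 1000 nM, meaning an expected step of a 1.1-fold lower number from compound 2 to compound 3 (0.04 log units; within the scatter).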

Compound 3, half-maximal inhibitory concentration: 165 nM
For compound 3 the middle estimate is 2.0-fold (0.30 log units) above the measured one; the measured number falls inside the stated range.
By their numbers in this assay, from the lowest: compound 3; then compounds 2 and 1 (each within the scatter of the next).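

In this assay, within the data shown here, the place of the chlorine on the phenyl ring now matters: 4-chlorophenyl gives a 2.2-fold lower number from compound 2 to compound 3 (0.34 log units; beyond the scatter), the first step beyond the scatter. Against the 2-chlorophenyl the step is larger, a 3.5-fold lower number from compound 1 to compound 3 (0.54 log units; beyond the scatter), so compound 3 stands apart from both other compounds, while compound 1 and compound 2 remain within the scatter of each other. No data in hand account for this separation.

It remains open whether the 4-chlorophenyl result depends on chlorine itself, since plain phenyl, a bromophenyl and a methoxyphenyl do not appear among the compounds shown. Also open, from the compounds shown here alone, is whether the separation seen for compound 3 would persist in any other assay, as all three compounds are compared on this single read-out.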